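Swapping allyl for prop-1-yn-1-yl on the shared core

A few compounds are considered here, and "the series" means these few. Any claim that something is new, unique, unknown or untested is made for them only; others in the source may bear on it.

In a functional assay on CCRF-CEM cells (Homo sapiens) (on this read-out lower numbers stand for higher toxicity in this test and higher numbers for lower toxicity in this test), compound 1 `CC1=C(N)[C@@]2(OS1(=O)=O)[C@@H](CO[Si](C)(C)C(C)(C)C)O[C@@H](n1cc(C)c(=O)n(C)c1=O)[C@@H]2O[Si](C)(C)C(C)(C)C` gives 10000 nM and compound 2 `C=CCC1=C(N)[C@@]2(OS1(=O)=O)[C@@H](CO[Si](C)(C)C(C)(C)C)O[C@@H](n1cc(C)c(=O)n(C)c1=O)[C@@H]2O[Si](C)(C)C(C)(C)C` gives 45000 nM as the higher of the two numbers. Compound 3 `CC#CC1=C(N)[C@@]2(OS1(=O)=O)[C@@H](CO[Si](C)(C)C(C)(C)C)O[C@@H](n1cc(C)c(=O)n(C)c1=O)[C@@H]2O[Si](C)(C)C(C)(C)C` changes one group of compound 2: prop-1-yn-1-yl in place of allyl on a double-bonded ring carbon in short, prop-1-yn-1-yl in place of allyl on a double-bonded ring carbon. Among the compounds with values here, the only measured step that bears on this is a 4.5-fold higher number from compound 1 to compound 2 (0.65 log units; beyond the scatter) and it is modest, so a step of similar modest size toward a lower number is expected, with a 2.0-fold lower number from compound 2 to compound 3 (0.31 log units; beyond the scatter) as the estimate. Compound 3 is expected at 22000 nM with an estimated range from 7000 nM to 60000 nM on this single-pair evidence.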

Compound 3, half-maximal cytotoxic concentration: 5000 nM
The estimate for compound 3 lay 4.4-fold (0.64 log units) above the measured number; the whole stated range lies above it.
By their numbers in this assay, from the lowest: compounds 3 and 1 (each within the scatter of the next); then compound 2.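

At this position on the double-bonded ring carbon, allyl and prop-1-yn-1-yl have the same carbon count, yet this assay shows a 9.0-fold lower number from compound 2 to compound 3 (0.95 log units; beyond the scatter), so carbon count alone does not set the number here. Prop-1-yn-1-yl in place of methyl gives a 2.0-fold lower number from compound 1 to compound 3 (0.30 log units; within the scatter), so adding carbons at this position does not by itself shift the number. Nothing measured here gives a reason for the gap between allyl and prop-1-yn-1-yl.

On these data alone, it remains open whether a saturated propyl chain would sit with allyl or with methyl. The compounds shown also leave open how an amine or a longer alkyne chain would fare at this position.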